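From 4-methylphenyl to phenyl at the assay limit

This account rests on a few compounds, and the source may have more. Where it says the series, first, only, none or still open, it means among the compounds named here.

Compounds measured in a functional assay on thoracic aorta (Rattus norvegicus, strain Wistar), with a stated time of 15 min; on this read-out lower numbers stand for an effect already at smaller amounts and higher numbers for an effect only at larger amounts of compound:
Compound 1 `CC(C)Oc1ccc(Br)cc1C(C)NC(=O)N(C)S(=O)(=O)c1ccccc1`: 32100 nM
Compound 2 `CCOc1ccc(F)cc1C(C)NC(=O)NS(=O)(=O)c1ccc(Cl)cc1`: > 300000 nM (a limit)
Compound 3 `COc1ccc(Br)cc1C(C)NC(=O)NS(=O)(=O)c1ccc(C)cc1`: > 300000 nM (a limit)

Only compound 1 has a measured number, and it differs from compound 3 in more than one place. Compound 3 gives > 300000 nM, which is a limit of the assay and not a number. Compound 2 gives > 300000 nM, which is also a limit. From the compounds shown here alone, the picture so far is therefore (the limit of > 300000 nM in this assay, at which 2 of the 3 values shown sit), and how far compound 3 lies beyond its limit is unknown.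

The next compound to be tested is compound 4 `COc1ccc(Br)cc1C(C)NC(=O)NS(=O)(=O)c1ccccc1`. It differs from compound 3 by a single small edit, 4-methylphenyl to phenyl, with hydrogen in place of methyl on an aromatic carbon. For the measured compounds named here, no pair of measured compounds shows what this edit does, so any forecast is uncertain. With so small a change, no step beyond the usual scatter is expected, and no direction can be favoured. Compound 4 will most likely stay at the limit and yield no number. The expected step is a number no higher from compound 3 to compound 4 (the limit leaves the size open). For compound 4 the estimate is 300000 nM, with an expected range from 100000 nM to 900000 nM.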

Compound 4, half-maximal effective concentration: > 300000 nM
Compound 4: no number, only a limit; the forecaster's own chance of this, stated with the estimate: 75%; the middle value sits exactly at the limit.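

Compound 3 and compound 4 each give only a limit and not a number, so no step can be read between them: the limit of > 300000 nM in this assay, at which 3 of the 4 values shown sit.

The compounds shown leave open whether hydrogen in place of methyl on an aromatic carbon changes the effect at all, and how far compound 3 and compound 4 lie beyond their limits.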